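Fluoro in place of nitro on a shared oxindole-benzimidazole core

The source may report more compounds than this note shows. Statements on the series, on what has been measured and on what is new or still open speak of the compounds shown alone.

Compound 1: `CCn1c(/C=C2/C(=O)Nc3ccccc32)nc2ccccc21` — > 50000 nM
Compound 2: `Cn1c(/C=C2/C(=O)Nc3ccc([N+](=O)[O-])cc32)nc2ccccc21` — "not determined" (no result reported)

The study measures cytotoxicity in a functional assay on MDA-MB-231 cells (Homo sapiens) for cytotoxicity, read by MTT assay, with a stated time of 48 h; a higher number here means a weaker inhibitor, a lower number a stronger inhibitor. Compound 1 gives only a limit of the assay, > 50000 nM, and no number. For the measured compounds named here, compound 2 has no result in this assay at all, so the only information is the limit of > 50000 nM in this assay, at which 1 of the 2 values shown sits. Compound 3, `Cn1c(/C=C2/C(=O)Nc3ccc(F)cc32)nc2ccccc21`, is the unmeasured analogue of compound 2. The change fluoro in place of nitro on an aromatic carbon is a small one at one position of the core. Going by the values given here, no step between measured compounds exists here, so the size of the step in this assay cannot be read from the data; given that the one measured value is a limit, no movement beyond the scatter is expected in either direction. Compound 3 is therefore estimated at 40000 nM, with a range of 8000 nM to 50000 nM.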

Compound 3, half-maximal inhibitory concentration: 21700 nM
For compound 3 the middle estimate is 1.8-fold (0.27 log units) above the measured one; the measured number falls inside the stated range.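

In this assay, for the compounds shown here, compound 3 gives 21700 nM, but this result yields no step that can be read from compound 2 to compound 3. The compounds shown leave open how fluoro and nitro on the shared core compare in this assay.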